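Bromo in place of hydrogen: compound 3 to compound 4

The compounds below may be only part of what the source reports. "The series", "measured", "known", "first", "only" and "open" are said of these compounds alone.

Measured in a functional assay on HCT-116 cells (Homo sapiens) for cytotoxicity, read by MTT assay, with a stated time of 72 h; a higher number here means a weaker inhibitor, a lower number a stronger inhibitor:
- compound 1 `Nc1ccccc1NC(=O)c1ccc(NC(=S)NCc2cccc(F)c2)cc1`: 5900 nM
- compound 2 `Nc1ccccc1NC(=O)c1ccc(NC(=S)NCc2ccc(Cl)nc2)cc1`: 6100 nM
- compound 3 `Nc1ccccc1NC(=O)c1ccc(NC(=S)NCc2cccnc2)cc1`: 1000 nM

Compound 3 holds the lowest number of the three. The steps leading to it, a 5.9-fold lower number from compound 1 to compound 3 (0.77 log units; beyond the scatter) and a 6.1-fold lower number from compound 2 to compound 3 (0.79 log units; beyond the scatter), both lie beyond the scatter, while a 1.0-fold higher number from compound 1 to compound 2 (0.01 log units; within the scatter) does not.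

The next compound is compound 4 `Nc1ccccc1NC(=O)c1ccc(NC(=S)NCc2cncc(Br)c2)cc1`, and the change is bromo in place of hydrogen on an aromatic carbon, two atoms from the ring nitrogen.

The closest evidence is a 6.1-fold lower number from compound 2 to compound 3 (0.79 log units; beyond the scatter). Read backwards, it shows that the one halogen-bearing pyridin-3-yl compound has the higher number. The step of a 5.9-fold lower number from compound 1 to compound 3 (0.77 log units; beyond the scatter) fits this only loosely, as it replaces 3-fluorophenyl. That is a single pair, and the 6-chloropyridin-3-yl of compound 2 and the 5-bromopyridin-3-yl of compound 4 differ in both halogen and place. Among the measured compounds shown here, no measured compound carries bromo or any group at this place, so the direction is tentative.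

In this assay the expected change is a 3.0-fold higher number from compound 3 to compound 4 (0.48 log units; beyond the scatter), somewhat smaller than the chloro step. Compound 4 is estimated at 3000 nM, with an expected range of 1000 nM to 8000 nM.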

Compound 4, half-maximal inhibitory concentration: 9200 nM
The estimate for compound 4 lay 3.1-fold (0.49 log units) below the measured number; measured number above the stated range.
By their numbers in this assay, from the lowest: compound 3; then compounds 1, 2 and 4 (each within the scatter of the next).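

In this assay, among the compounds shown here, a group at this place, two atoms from the ring nitrogen, proves no more tolerated than the chloro of the 6-chloropyridin-3-yl: bromo in place of hydrogen gives a 9.2-fold higher number from compound 3 to compound 4 (0.96 log units; beyond the scatter), a step beyond the scatter, and the earlier compounds held nothing at this place. The other two new steps, a 1.5-fold higher number from compound 2 to compound 4 (0.18 log units; within the scatter) and a 1.6-fold higher number from compound 1 to compound 4 (0.19 log units; within the scatter), both lie within the scatter, so compounds 1, 2 and 4 form one level, and compound 3, with its unsubstituted pyridin-3-yl, stands alone with the lowest number. Both halogen-bearing pyridin-3-yl compounds thus sit above compound 3, with no pyridine in the set going against this, though the two differ in halogen and in place, and nothing at hand explains the rise.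

For the compounds shown here, whether the rise belongs to bromo itself or to any group at this place stays open, since only this one group occupies it. A fluoro, a methoxy or an amine on the same ring carbon would separate these readings, and a methyl would show whether a non-halogen group behaves the same way.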